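This account rests on a few compounds, and the source may have more. Where it says the series, first, only, none or still open, it means among the compounds named here.

Compound 1 `CN1CCN(CC#CCn2ccnc2)C1=O`: > 100 mg/kg (a limit)
Compound 2 `CC(C#CCN1CCCC1)N1CCN(C)C1=O`: 25 mg/kg

Going by the values given here, in a functional assay on the whole organism for antagonist activity, with Mus musculus as the target (on this read-out higher numbers stand for an effect only at larger amounts of compound and lower numbers for an effect already at smaller amounts), compound 2 gives 25 mg/kg, the only actual number so far. Compound 1 reads > 100 mg/kg, which is a limit of the assay and not a number.

The next compound is compound 3 `CC(C#CCn1ccnc1)N1CCN(C)C1=O`. It has 1H-imidazol-1-yl in place of pyrrolidin-1-yl on a saturated chain carbon bound to a triple-bonded carbon. Among the compounds with values here, no measured pair isolates this change, so the expectation rests on little. Compound 1 also carries 1H-imidazol-1-yl, and its reading of > 100 mg/kg suggests that larger doses will be needed. The estimated 4.0-fold higher number from compound 2 to compound 3 (0.60 log units; beyond the scatter) in this assay therefore points towards larger doses, beyond the usual scatter. For compound 3 the expected value is 100 mg/kg, with an estimated range of 35 mg/kg to 300 mg/kg.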

Compound 3, dose for half-maximal effect: 21 mg/kg
Compound 3: the middle estimate sits 4.8-fold (0.68 log units) above what was measured; the whole stated range lies above it.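

In this assay, 1H-imidazol-1-yl in place of pyrrolidin-1-yl on a saturated chain carbon bound to a triple-bonded carbon gives a 1.2-fold lower number from compound 2 to compound 3 (0.08 log units; within the scatter), so this read-out does not separate the two groups at this position. The imidazole alone therefore does not account for the reading of compound 1: methyl in place of hydrogen on a saturated chain carbon bound to an amide-type nitrogen in a ring and a triple-bonded carbon gives an at least 4.7-fold lower number from compound 1 to compound 3 (0.67 log units; beyond the scatter). Compound 1 reads > 100 mg/kg, a limit of the assay and not a number, so the full size of this step stays open: the limit of > 100 mg/kg in this assay, at which 1 of the 3 values shown sits.

From the compounds shown here alone, whether methyl in place of hydrogen gives a similar step when pyrrolidin-1-yl is present remains open. Also open, going by these compounds, is how ethyl at that chain carbon, or dimethylamino in place of the ring, would read.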